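Swapping the Pyrrole Arm for a Nitrophenol Arm

The source may hold more compounds than are shown below. What is called first, only, known or untested is meant among the compounds shown, and "the series" means these compounds.

Of the compounds shown here, three share one core and have been measured in a functional assay on DU-145 cells (Homo sapiens) for inhibition, read by trypan blue exclusion, with a stated time of 96 h; a lower number here means a stronger inhibitor of growth, a higher number a weaker inhibitor of growth. Compound 1 `O=C(/C(=C\c1ccc(Br)cc1)SCc1ccc(Cl)cc1)c1ccc(Cl)cc1` gives 1000 nM, compound 2 `CSc1ccc(/C=C(/SCc2ccc(Cl)cc2)C(=O)c2ccc(Cl)cc2)cc1` gives 25000 nM, and compound 3 `O=C(/C(=C\c1ccc[nH]1)SCc1ccc(Cl)cc1)c1ccc(Cl)cc1` gives 10000 nM, which places compound 3 second highest of the three numbers. Compound 4 `O=C(/C(=C\c1ccc(O)c([N+](=O)[O-])c1)SCc1ccc(Cl)cc1)c1ccc(Cl)cc1` awaits measurement; the change from compound 3 is 4-hydroxy-3-nitrophenyl in place of 1H-pyrrol-2-yl on a double-bonded chain carbon bound to a double-bonded chain carbon. The steps of a 10-fold higher number from compound 1 to compound 3 (1.00 log units; beyond the scatter) and a 2.5-fold lower number from compound 2 to compound 3 (0.40 log units; beyond the scatter) show that the group on this chain carbon moves the number in both directions, and a 25-fold higher number from compound 1 to compound 2 (1.40 log units; beyond the scatter) shows that substituents on a phenyl ring there matter greatly. A six-membered ring returns, so a modest step down is expected, a 1.7-fold lower number from compound 3 to compound 4 (0.22 log units; within the scatter). Compound 4 is thus estimated at 6000 nM, with a range from 1500 nM to 25000 nM.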

Compound 4, concentration for 50% growth inhibition: 10000 nM
Beside the measured number, compound 4's estimate is 1.7-fold (0.22 log units) below it, within the range that was stated.
By their numbers in this assay, from the lowest: compound 1; then compounds 3 and 4 (each within the scatter of the next); then compound 2.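

In this assay, the 4-hydroxy-3-nitrophenyl group, with 10 heavy atoms, reads like the 1H-pyrrol-2-yl group, with 5, showing no change at the digits printed from compound 3 to compound 4 (within the scatter); for this pair, the size of the group does not set the number. Among the phenyl groups at this position, the substituents separate the numbers, with a 2.5-fold lower number from compound 2 to compound 4 (0.40 log units; beyond the scatter) and a 10-fold higher number from compound 1 to compound 4 (1.00 log units; beyond the scatter). No measurement shown explains these differences.

From the compounds shown here alone, the separate contributions of the hydroxy and nitro groups in compound 4 remain open. So does how an amine or a carboxylic acid on the phenyl ring would read.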